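The source may hold more compounds than are shown below. What is called first, only, known or untested is meant among the compounds shown, and "the series" means these compounds.

In a physicochemical assay for solubility, using the shake flask method, in simulated intestinal fluid, measured as kinetic solubility, with a stated time of 2 h, at 25 degrees C, at pH 6.5 (on this read-out higher numbers stand for higher solubility and lower numbers for lower solubility), compound 1 (`Cc1noc(-c2nc(C)c3c(c2N)C(=O)N(Cc2ccc(C(F)(F)F)cc2)C3=O)n1`) gives < 5000 nM as a limit of the assay and not a number. Compound 2 (`Cc1noc(-c2nc(C)c3c(c2N)C(=O)N(Cc2ccccc2F)C3=O)n1`) gives < 5000 nM as a limit too, so it has no number of its own and stands at the limit of < 5000 nM in this assay, at which 2 of the 2 values shown sit, in this account. Compound 3 (`Cc1noc(-c2nc(C)c3c(c2N)C(=O)N(Cc2ccccc2C(F)(F)F)C3=O)n1`) carries trifluoromethyl in place of fluoro on an aromatic carbon, ortho to a large group, and the count trifluoromethyl in place of fluoro on an aromatic carbon sets out that change from compound 2. Among the compounds with values here, the only measured step is a step that the two limits leave unreadable from compound 1 to compound 2 and it gives no size to scale from, so no step beyond the scatter is expected in this assay in either direction. The estimated step is a step that the limit leaves unreadable from compound 2 to compound 3 on this reading. Compound 3 is expected near 3000 nM with an estimated range from 800 nM to 5000 nM in this assay.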

Compound 3, solubility: < 5000 nM
Compound 3: no number, only a limit (the forecaster's own chance of this, stated with the estimate: 85%); the middle value does not contradict the limit.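

In this assay compound 3 gives < 5000 nM, a limit of the assay and not a number. Within the data shown here, no step from compound 1 or compound 2 to compound 3 can be read. The compounds shown leave open how compound 1, compound 2 and compound 3 rank against one another on solubility.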